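Amide nitrogen substituent change in a thienylmethyl amide series

The source may hold more compounds than are shown below. What is called first, only, known or untested is meant among the compounds shown, and "the series" means these compounds.

Measured so far:
compound 1 `CCN(Cc1cccs1)C(=O)C[C@@H](O)c1ccccc1` — "not active" (no number reported)
compound 2 `Cc1ccc(OCC(=O)N(Cc2cccs2)c2nccs2)cc1` — 2240 nM
compound 3 `O=C(COc1ccc2c(c1)CCC2)N(Cc1cccs1)c1ccn[nH]1` — 0.001 nM

In an assay on HEK293 cells for agonist activity at transient receptor potential cation channel subfamily M member 8 (Homo sapiens), read by fluorescence and calcium flux, with a stated time of 15 min (a lower number here means that less compound is needed, a higher number that more compound is needed for the effect), compound 2 gives 2240 nM, the highest of the two numbers reported; compound 1 is reported only as inactive, without a number. Compound 3, which carries a different aryloxy group as well as a different ring on the amide nitrogen, gives 0.001 nM in this assay, far lower than compound 2 and beyond the scatter. Within the data shown here, no pair of compounds measured so far differs in a single place, so no single step can be read off.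

Compound 4 `Cc1ccc(OCC(=O)N(Cc2cccs2)c2ccn[nH]2)cc1` differs from compound 2 in one place: 1H-pyrazol-5-yl in place of 1,3-thiazol-2-yl on an amide-type nitrogen. The ring that enters is the same ring that sits on the amide nitrogen of compound 3, while the aryloxy part of compound 2 is kept. On that basis a large step to a lower number is expected for compound 4, a 110-fold lower number from compound 2 to compound 4 (2.05 log units; beyond the scatter), well beyond the scatter. The size of that step is uncertain because compound 3 also carries a different aryloxy group and gives 0.001 nM. Compound 4 is estimated at 20 nM, within 0.5 nM to 800 nM.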

Compound 4, half-maximal effective concentration: 0.2 nM
Compound 4: middle estimate off by 100-fold (2.00 log units), on the high side, outside the stated range (below it).
By their numbers in this assay, from the lowest: compound 3; then compound 4; then compound 2.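

In this assay, the ring on the amide-type nitrogen now has a measured effect of its own: 1H-pyrazol-5-yl in place of 1,3-thiazol-2-yl gives an 11000-fold lower number from compound 2 to compound 4 (4.05 log units; beyond the scatter) while the aryloxy part stays unchanged. The earlier compounds shown here offered no single step, so the low number of compound 3 could not be assigned to either its ring or its aryloxy group. Among these compounds, the entering ring counts one hydrogen-bond donor where the leaving ring counts none, but no measurement ties the step to this or to any other feature of the two rings.

Open, on these data alone, is whether the same ring change gives a step of similar size with the aryloxy group of compound 3. Also open, as far as these compounds go, is how a phenyl ring or an N-methylpyrazole would read on this amide-type nitrogen.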